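Cyclopentylamino to anilino on the shared core

The source may hold more compounds than are shown below. What is called first, only, known or untested is meant among the compounds shown, and "the series" means these compounds.

Compound 2 `O=C1C=C(NC2CCCC2)C(=O)c2c1nc1n2[C@H]2OC[C@@H](O)[C@H]2OC1` carries a cyclopentyl on the amine nitrogen of the shared core. In a functional assay on MCF7 cells (Homo sapiens) for inhibition, read by sulforhodamine B assay (a lower number here means a stronger inhibitor, a higher number a weaker inhibitor), compound 2 gives only a limit, > 16000 nM, not a number (the limit of > 16000 nM in this assay, at which 1 of the 3 values shown sits). Compound 4 `O=C1C=C(Nc2ccccc2)C(=O)c2c1nc1n2[C@H]2OC[C@@H](O)[C@H]2OC1` differs by phenyl in place of cyclopentyl on an amine nitrogen. Among the measured compounds shown here, the one measured step on this amine nitrogen runs between two aryl variants. Compound 1 `O=C1C(Nc2ccccc2F)=CC(=O)c2c1nc1n2[C@H]2OC[C@@H](O)[C@H]2OC1` gives a limit of > 4000 nM in this assay. Compound 3 `COc1ccc(NC2=CC(=O)c3c(nc4n3[C@H]3OC[C@@H](O)[C@H]3OC4)C2=O)cc1` gives 4470 nM in this assay, so the step that the limit leaves unreadable from compound 1 to compound 3 is unreadable because of the limit (the limit of > 4000 nM in this assay, at which 1 of the 3 values shown sits). Nothing measured sizes the move from cyclopentyl to phenyl. Compound 4 is therefore expected near the aryl variants, estimated at 6000 nM within 2500 nM to 20000 nM. The expected step of an at least 2.6-fold lower number from compound 2 to compound 4 (0.42 log units; beyond the scatter) cannot be sized against a limit.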

Compound 4, half-maximal inhibitory concentration: > 4000 nM
Compound 4 gave a limit, no number; the forecaster's own chance of this, stated with the estimate: 40%; the middle value lies beyond the limit too.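

In this assay, among the compounds shown here, compound 2 and compound 4 both give only limits, so no step from one to the other can be read. From the compounds shown here alone, how far phenyl and cyclopentyl on the amine nitrogen differ in this assay stays open.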